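Moving from a chlorophenyl to a naphthyl amide

This account rests on a few compounds, and the source may have more. Where it says the series, first, only, none or still open, it means among the compounds named here.

Measured so far, with their numbers in an assay on isolated protein for inhibition of Caspase-8 (Homo sapiens); a lower number here means a stronger inhibitor, a higher number a weaker inhibitor:
Compound 1 `O=C1C[C@H](NC(=O)[C@@H]2COC[C@@H]3C/C=C\C[C@H](NC(=O)c4ccc(C(F)(F)F)cc4)C(=O)N32)C(O)O1` gives 6450 nM in this assay.
Compound 2 `O=C1C[C@H](NC(=O)[C@@H]2COC[C@@H]3C/C=C\C[C@H](NC(=O)c4ccccc4C(F)(F)F)C(=O)N32)C(O)O1` gives 670 nM in this assay.
Compound 3 `O=C1C[C@H](NC(=O)[C@@H]2COC[C@@H]3C/C=C\C[C@H](NC(=O)c4cccc(Cl)c4)C(=O)N32)C(O)O1` gives 1550 nM in this assay.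

Among these three, compound 3 stands in the middle: the step from compound 1 was a 4.2-fold lower number from compound 1 to compound 3 (0.62 log units; beyond the scatter), while the step of a 2.3-fold higher number from compound 2 to compound 3 (0.36 log units; beyond the scatter) separates it from compound 2. All three share the same core and differ only in the aromatic group attached to the carbonyl carbon, and those swaps moved the numbers by modest amounts, as the step of a 9.6-fold lower number from compound 1 to compound 2 (0.98 log units; beyond the scatter) also shows.

Compound 4 `O=C1C[C@H](NC(=O)[C@@H]2COC[C@@H]3C/C=C\C[C@H](NC(=O)c4ccc5ccccc5c4)C(=O)N32)C(O)O1` carries the change (naphthalen-2-yl in place of 3-chlorophenyl on a carbonyl carbon). Going by the values given here, no measured pair involves a naphthalen-2-yl group, so nothing directly tells how this swap will read; the measured steps only suggest that aromatic exchanges at this position shift the number modestly in either direction. Compound 4 is therefore expected near compound 3, with the step of a 1.0-fold lower number from compound 3 to compound 4 (0.01 log units; within the scatter) as the estimate. The expected value for compound 4 is 1500 nM, within the range 400 nM to 6000 nM.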

Compound 4, half-maximal inhibitory concentration: 2590 nM
For compound 4 the middle estimate is 1.7-fold (0.24 log units) below the measured one; the range from low to high includes it.
By their numbers in this assay, from the lowest: compound 2; then compounds 3 and 4 (each within the scatter of the next); then compound 1.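

In this assay, a group with two six-membered aromatic rings on this carbonyl carbon reads like the single-ring 3-chlorophenyl group: a 1.7-fold higher number from compound 3 to compound 4 (0.22 log units; within the scatter) leaves the two compounds indistinguishable. The naphthalen-2-yl group also falls inside the span set by the two trifluoromethyl isomers, with a 3.9-fold higher number from compound 2 to compound 4 (0.59 log units; beyond the scatter) on one side and a 2.5-fold lower number from compound 1 to compound 4 (0.40 log units; beyond the scatter) on the other, so the larger aromatic group does not take the number outside what the single-ring groups already gave. Nothing available here explains any of these steps.

From the compounds shown here alone, whether naphthalen-1-yl would read like naphthalen-2-yl remains open. So does whether a pyridine ring, a saturated cyclohexyl ring or a group carrying a carboxylic acid would stay within this span.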